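This account rests on a few compounds, and the source may have more. Where it says the series, first, only, none or still open, it means among the compounds named here.

Working notes on the series, read in a functional assay on L02 cells (Homo sapiens) for inhibition; on this read-out lower numbers stand for stronger inhibition and higher numbers for weaker inhibition. Compound 1 `O=C(CC(CC(=O)NC1Cc2ccccc2C1)c1ccc(Cl)cc1)NCCN1CCCCC1` gives 70400 nM and compound 2 `CCN(CC)CCNC(=O)CC(CC(=O)NC1Cc2ccccc2C1)c1ccc(Cl)cc1` gives 76700 nM. The step of a 1.1-fold higher number from compound 1 to compound 2 (0.04 log units; within the scatter) shows these two numbers as level, so compound 2 stands with compound 1 among the only two numerical results. Compound 3 `CCN(CC)CCNC(=O)CC(CC(=O)NC1Cc2ccccc2C1)c1ccccc1` reports only a limit, > 100000 nM. The step of an at least 1.3-fold higher number from compound 2 to compound 3 (0.11 log units; that floor lies within the scatter) is therefore a floor and not a measured size.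

Compound 4 `CCN(CC)CCNC(=O)CC(CC(=O)N(C)C1Cc2ccccc2C1)c1ccc(Cl)cc1` differs from compound 2 by methyl in place of hydrogen on an amide-type nitrogen. Neither measured step touches an amide-type nitrogen: one exchanges piperidin-1-yl for diethylamino, and the other exchanges chloro for hydrogen. Within the data shown here, they bear on the new change only as a guide to how little these numbers have moved so far, so no direct precedent exists for its size or direction. A step beyond the scatter is not expected, and a slight drift towards weaker inhibition is the only lean. The expected change is a 1.1-fold higher number from compound 2 to compound 4 (0.04 log units; within the scatter). A result reported only as a limit would not be surprising, given (the limit of > 100000 nM in this assay, at which 1 of the 3 values shown sits). For compound 4 the estimate is 85000 nM, with an expected range of 45000 nM to 150000 nM.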

Compound 4, half-maximal inhibitory concentration: 56500 nM
Estimate against measurement, compound 4: 1.5-fold (0.18 log units) above; the measured number falls inside the stated range.
By their numbers in this assay, from the lowest: compounds 4, 1 and 2 (each within the scatter of the next). At a limit, above all of these: compound 3.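

Methyl in place of hydrogen on the amide-type nitrogen whose other neighbours are a carbonyl carbon and a saturated ring carbon gives the first reading at this position, with a 1.4-fold lower number from compound 2 to compound 4 (0.13 log units; within the scatter) in this assay. On this single pair the amide hydrogen is not required for a numerical result, and the added methyl leaves the read-out level, so the position tolerates this one small change without a step beyond the scatter. Even so, the set still includes a result that is not a number, which limits how much the level values can show: the limit of > 100000 nM in this assay, at which 1 of the 4 values shown sits.

From the compounds shown here alone, whether a larger group on this nitrogen, such as ethyl or benzyl, would move the number beyond the scatter remains open, as does whether the methyl step would stay level with piperidin-1-yl in place of diethylamino. Also open, going by these compounds, is whether a group other than chloro on the aromatic carbon, such as fluoro or methoxy, would bring the numbers out of their present range.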